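A new aryl group on the sulfonyl sulfur

The compounds below may be only part of what the source reports. "The series", "measured", "known", "first", "only" and "open" are said of these compounds alone.

Measured in a functional assay on VCaP cells (Homo sapiens) for antiproliferative activity, read by propidium iodide staining, with a stated time of 96 h; on this read-out lower numbers stand for stronger inhibition and higher numbers for weaker inhibition:
Compound 1 `CC(O)(CSc1ccccc1OC(F)(F)F)C(=O)Nc1ccc(S(F)(F)(F)(F)F)cc1`: 10100 nM
Compound 2 `CC(O)(CS(=O)(=O)c1ccc(S(F)(F)(F)(F)F)cc1)C(=O)Nc1ccc(S(F)(F)(F)(F)F)cc1`: 15700 nM
Compound 3 `CC(O)(CS(=O)(=O)c1ccc(C(F)(F)F)cc1)C(=O)Nc1ccc(S(F)(F)(F)(F)F)cc1`: 27700 nM

Repeat measurements of this kind naturally scatter, so small gaps between numbers carry little meaning. Compound 3, at 27700 nM, stands at the high end of this small set, together with compound 2. The number for compound 1, 10100 nM, lies lower than that of compound 3, and this gap goes beyond the scatter.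

The next structure is compound 4 `CC(O)(CS(=O)(=O)c1cccc(OC(F)(F)F)c1)C(=O)Nc1ccc(S(F)(F)(F)(F)F)cc1`. It has 3-(trifluoromethoxy)phenyl in place of 4-(trifluoromethyl)phenyl on a sulfonyl sulfur.

Among the compounds with values here, no measured step makes this exact change. The closest guide is a 1.8-fold higher number from compound 2 to compound 3 (0.25 log units; within the scatter). That step also exchanges a fluorine-bearing group on an aromatic carbon, and it stays within the scatter. Compound 1 also carries a trifluoromethoxy group, but it differs from compound 4 in more than one place, so it offers only a loose hint.

Therefore, no step beyond the scatter is expected in this assay. The expected step is a 1.4-fold lower number from compound 3 to compound 4 (0.14 log units; within the scatter). For compound 4 the estimated value is 20000 nM, with an expected range from 9000 nM to 45000 nM.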

Compound 4, half-maximal inhibitory concentration: 23700 nM
Beside the measured number, compound 4's estimate is 1.2-fold (0.07 log units) below it; the range from low to high includes it.
By their numbers in this assay, from the lowest: compounds 1, 2, 4 and 3 (each within the scatter of the next, the first and the last beyond it).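

In this assay, 3-(trifluoromethoxy)phenyl in place of 4-(trifluoromethyl)phenyl on a sulfonyl sulfur gives a 1.2-fold lower number from compound 3 to compound 4 (0.07 log units; within the scatter), so these two aryl groups cannot be told apart on this read-out. Within the data shown here, the earlier step at this position, a 1.8-fold higher number from compound 2 to compound 3 (0.25 log units; within the scatter), exchanged only one fluorine-bearing group for another under the same name pattern, whereas this change alters the group, the number in its name and the count of hydrogen-bond acceptors all at once, and the result still stays within the scatter. Since the group and the number in its name change together, their separate contributions cannot be read from this pair, and no measured information here explains the result.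

The sulfonyl compounds shown all carry fluorine-bearing groups on the aryl ring, which leaves open whether an amine or a carboxylic acid in that role would give a number beyond the scatter of compound 3. On these data alone, compound 1 differs from compound 4 in more than one place, so what the sulfonyl sulfur itself contributes also remains open.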